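Dimethylamino for trifluoromethyl on the anilino ring

The compounds below may be only part of what the source reports. "The series", "measured", "known", "first", "only" and "open" are said of these compounds alone.

Measured so far in a functional assay on K562 cells (Homo sapiens) for antiproliferative activity, read by CellTiter-Glo and CCK-8 assay, with a stated time of 72 h; on this read-out lower numbers stand for stronger inhibition of growth and higher numbers for weaker inhibition of growth:
compound 1 `Cc1ccc(Nc2ncc3c(n2)N(C)C(=O)N(c2cc(NC(=O)c4cccc(C(F)(F)F)c4)ccc2C)C3)cc1C`, compound 1 gives 17 nM
compound 2 `Cc1ccc(NC(=O)c2cccc(C(F)(F)F)c2)cc1N1Cc2cnc(Nc3ccc(C)c(C(F)(F)F)c3)nc2N(C)C1=O`, compound 2 gives 29 nM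
compound 3 `Cc1ccc(NC(=O)c2cccc(C(F)(F)F)c2)cc1N1Cc2cnc(OC3CCN(C(=O)OC(C)(C)C)CC3)nc2N(C)C1=O`, compound 3 gives 29 nM

Compound 2 stands level with compound 3 at the digits shown, and the two together carry the highest numbers of the three; compound 1 is nearest below, with a gap that stays within the scatter.

Compound 4 `Cc1ccc(Nc2ncc3c(n2)N(C)C(=O)N(c2cc(NC(=O)c4cccc(C(F)(F)F)c4)ccc2C)C3)cc1N(C)C` differs from compound 2 by dimethylamino in place of trifluoromethyl on an aromatic carbon. Within the data shown here, no measured pair bears directly on this exchange. Among the measured compounds shown here, the only related step, a 1.7-fold higher number from compound 1 to compound 2 (0.23 log units; within the scatter), swaps methyl for trifluoromethyl at the same aromatic carbon and stays within the scatter; the present change replaces that trifluoromethyl with dimethylamino, ortho to the methyl group. On this basis no step beyond the scatter is expected in this assay, so the expected step is a 1.2-fold lower number from compound 2 to compound 4 (0.06 log units; within the scatter). Compound 4 is therefore estimated at 25 nM, with a range from 8 nM to 80 nM.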

Compound 4, concentration for 50% growth inhibition: 28 nM
The estimate for compound 4 lay 1.1-fold (0.05 log units) below the measured number, within the range that was stated.
By their numbers in this assay, from the lowest: compounds 1, 4, 2 and 3 (each within the scatter of the next).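

In this assay the steps of a 1.0-fold lower number from compound 2 to compound 4 (0.02 log units; within the scatter) and a 1.6-fold higher number from compound 1 to compound 4 (0.22 log units; within the scatter) both stay within the scatter, so this aromatic carbon, ortho to a methyl group, carries trifluoromethyl, methyl or dimethylamino with no separable difference in growth inhibition. Dimethylamino brings a hydrogen-bond acceptor that trifluoromethyl lacks, and this exchange produces no step beyond the scatter here. No available measurement accounts for this flat response.

Still open, going by these compounds, is whether a carboxylic acid, a morpholine or an amine on a longer chain at this carbon would also stay within the scatter.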